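The source may hold more compounds than are shown below. What is called first, only, known or untested is meant among the compounds shown, and "the series" means these compounds.

Measured compounds in this study:
- compound 1 `C=CC1=C(C(=O)O)C(c2ccc(F)cc2)OC1`: > 100000 nM
- compound 2 `C=CC1=C(C(=O)O)C(c2ccc(OC)cc2)OC1`: > 100000 nM
- compound 3 `C=CC1=C(C(=O)NCc2ccc(Cl)cc2)C(c2ccc(F)cc2)OC1`: 36900 nM

In a functional assay on QGY7701 cells (Homo sapiens) for cytotoxicity, read by MTT assay, with a stated time of 24 h (a higher number here means a weaker inhibitor, a lower number a stronger inhibitor), compound 1 gives > 100000 nM, a limit of the assay rather than a number. Compound 2 gives > 100000 nM, again only a limit. The step that the two limits leave unreadable from compound 1 to compound 2 cannot be sized because the limit of > 100000 nM in this assay, at which 2 of the 3 values shown sit, covers both ends of it. Compound 3, an amide, gives 36900 nM in this assay, a real number inside the measured range.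

Compound 4 `C=CC1=C(C(=O)NCCCCC)C(c2ccc(OC)cc2)OC1` is not yet measured. It differs from compound 2 by pentylamino in place of hydroxy on a carbonyl carbon. Going by the values given here, no measured step matches this change; the only hint is that compound 3, an amide, is readable where the acid compound 1 is not. A step of an at least 2.5-fold lower number from compound 2 to compound 4 (0.39 log units; beyond the scatter) is therefore expected. Compound 4 is estimated at 40000 nM, between 12000 nM and 130000 nM.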

Compound 4, half-maximal inhibitory concentration: > 100000 nM
Compound 4 ended at the assay's limit; the forecaster's own chance of this, stated with the estimate: 30%; middle value at least 2.5-fold (0.39 log units) away from the limit.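

No step can be read between compound 2 and compound 4 because both give only a limit of the assay: the limit of > 100000 nM in this assay, at which 3 of the 4 values shown sit. The compounds shown leave open whether pentylamino in place of hydroxy changes the number in this assay at all, and by how much.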